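The source may report more compounds than this note shows. Statements on the series, on what has been measured and on what is new or still open speak of the compounds shown alone.

In an ADME assay on BHK-21 cells (Mesocricetus auratus) for cytotoxicity, read by MTT assay, with a stated time of 72 h (on this read-out lower numbers stand for higher toxicity in this test and higher numbers for lower toxicity in this test), compound 1 (`Cc1ccc(NCc2cn(-c3ccccc3)nc2-c2ccc(Cl)cc2)cc1`) gives > 100000 nM as a limit of the assay and not a number. Compound 2 (`Cc1ccc(NCc2cn(-c3ccccc3)nc2-c2ccccc2)cc1`) gives > 100000 nM as a limit too. Compound 3 (`Cc1ccc(-c2nn(-c3ccccc3)cc2CNc2ccc(Br)cc2)cc1`) likewise gives > 100000 nM as a limit. Compound 1 thus shares the limit of > 100000 nM in this assay, at which 3 of the 3 values shown sit, and has no exact number to start from.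

Compound 4 (`FC(F)(F)c1ccc(NCc2cn(-c3ccccc3)nc2-c2ccc(Cl)cc2)cc1`) keeps the core of compound 1 and carries trifluoromethyl in place of methyl on an aromatic carbon. For the measured compounds named here, only one measured step comes near this change, namely a step that the two limits leave unreadable from compound 1 to compound 2, and it concerns chloro rather than methyl. It gives no ground for a shift in either direction, so no step beyond the usual scatter is expected in this assay for this change. The expected move is a number no higher from compound 1 to compound 4 (the limit leaves the size open) and it remains an estimate only. For compound 4 the estimated value is 100000 nM, with an expected range from 50000 nM to 200000 nM, and the assay may well report only a limit again.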

Compound 4, half-maximal cytotoxic concentration: 17000 nM
Beside the measured number, compound 4's estimate is 5.9-fold (0.77 log units) above it, outside the stated range (below it).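

In this assay, for the compounds shown here, the change from 4-methylphenyl to 4-(trifluoromethyl)phenyl, on an aromatic carbon para to a large group, gives the first step that can be read: an at least 5.8-fold lower number from compound 1 to compound 4 (0.76 log units; beyond the scatter). The number for compound 4 therefore shows that this position can move the read-out towards higher toxicity in this test, which the unreadable earlier step at the chloro could not show. Compound 4 is the only compound shown that sits off the shared limit: the limit of > 100000 nM in this assay, at which 3 of the 4 values shown sit.

The compounds shown leave open how a methoxy, a nitrile or a carboxylic acid at this position would read, and so whether the step is particular to trifluoromethyl. They also leave open whether the same change gives a similar step on the core of compound 2, which has hydrogen in place of the chloro.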